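Acyl variation at the side-chain ester oxygen: working notes

The source may report more compounds than this note shows. Statements on the series, on what has been measured and on what is new or still open speak of the compounds shown alone.

Three compounds share one core and differ only in the group carried on the oxygen on a saturated carbon. Compound 1 `CC(C)=CC[C@@H](OC(=O)C1CCOC1)C1=CC(=O)c2c(O)ccc(O)c2C1=O` gives 47500 nM in a functional assay on DU-145 cells (Homo sapiens) for cytotoxicity, read by MTT assay; on this read-out higher numbers stand for weaker inhibition and lower numbers for stronger inhibition. Compound 2 `CC(C)=CC[C@@H](OC(=O)C1CCCO1)C1=CC(=O)c2c(O)ccc(O)c2C1=O` gives 10500 nM in this assay, and compound 3 `CCC(CO[C@H](CC=C(C)C)C1=CC(=O)c2c(O)ccc(O)c2C1=O)OC(C)=O` gives 25400 nM. Compound 2 stands lowest of the three numbers, with compound 3 nearest and compound 1 furthest; the gap between compound 1 and compound 3 is a 1.9-fold lower number from compound 1 to compound 3 (0.27 log units; within the scatter).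

Compound 4 `CC(C)=CC[C@@H](OC(=O)CC(C)(O)C(C)C)C1=CC(=O)c2c(O)ccc(O)c2C1=O` is not yet measured. Against compound 2 it shows one change: 2-hydroxy-2,3-dimethylbutyl in place of oxolan-2-yl on a carbonyl carbon. Among the measured compounds shown here, two measured steps bear on this position. Moving the ring attachment on the carbonyl carbon gave a 4.5-fold lower number from compound 1 to compound 2 (0.66 log units; beyond the scatter), so the acyl part is not indifferent. Exchanging the ring-bearing acyl group for an open chain gave a 2.4-fold higher number from compound 2 to compound 3 (0.38 log units; beyond the scatter). For the measured compounds named here, no measured pair tests a hydroxyl on the acyl chain, so that part of the change is untested. Taken together, a modest rise in number from compound 2 to compound 4 is expected, a 2.1-fold higher number from compound 2 to compound 4 (0.32 log units; beyond the scatter). For compound 4 the estimated value is 22000 nM, with a range from 8000 nM to 60000 nM.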

Compound 4, half-maximal inhibitory concentration: 16900 nM
Beside the measured number, compound 4's estimate is 1.3-fold (0.11 log units) above it; the measured number falls inside the stated range.
By their numbers in this assay, from the lowest: compounds 2, 4, 3 and 1 (each within the scatter of the next, the first and the last beyond it).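

In this assay, the open-chain 2-hydroxy-2,3-dimethylbutyl group replaces oxolan-2-yl on the carbonyl carbon with a 1.6-fold higher number from compound 2 to compound 4 (0.21 log units; within the scatter), so at this position neither the loss of the ring nor the entry of a hydrogen-bond donor gives a step that stands clear of the scatter. Among the compounds shown here, the same group also cannot be told apart from the 2-acetoxybutyl group on the oxygen, with a 1.5-fold lower number from compound 3 to compound 4 (0.18 log units; within the scatter), yet it does separate from the oxolan-3-yl ester, with a 2.8-fold lower number from compound 1 to compound 4 (0.45 log units; beyond the scatter), so a ring on the carbonyl carbon is not needed to reach the lower part of this small set, and compound 1 remains the one ester apart from compound 2 and compound 4. No information is available that would account for these steps.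

The compounds shown do not separate the contribution of the hydroxyl in compound 4 from that of its branched carbon chain. Also open, going by these compounds, is whether an amine or a carboxylic acid on the acyl chain, or a longer unbranched chain, would move the number beyond the scatter from compound 2.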